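Trimming the Side Chain of Compound 1

The compounds below may be only part of what the source reports. "The series", "measured", "known", "first", "only" and "open" are said of these compounds alone.

Compound 1 `CN1CCN(CCCCCn2c3c(c4ccccc42)C(=O)c2c[n+]([O-])c4ccccc4c2C3=O)CC1`: 1260 nM
Compound 2 `O=C1c2c[n+]([O-])c3ccccc3c2C(=O)c2c1c1ccccc1n2Cc1cn([C@H]2C[C@H](O)[C@@H](CO)O2)nn1`: 530 nM
Compound 3 `O=C1c2c[n+]([O-])c3ccccc3c2C(=O)c2c1c1ccccc1n2Cc1cn([C@H]2O[C@H](CO)[C@@H](O)[C@H]2O)nn1`: 1490 nM

In a functional assay on MCF7 cells (Homo sapiens) for cytotoxicity, read by MTT assay, with a stated time of 72 h (on this read-out lower numbers stand for stronger inhibition and higher numbers for weaker inhibition), compound 1 gives 1260 nM, the second highest of the three numbers; compound 3 lies within the scatter of it, while compound 2 gives the lowest number. Compound 4 `CN(C)CCCCn1c2c(c3ccccc31)C(=O)c1c[n+]([O-])c3ccccc3c1C2=O` differs from compound 1 by dimethylamino in place of (4-methylpiperazin-1-yl)methyl on a saturated chain carbon, four bonds along the chain from an aromatic nitrogen. Among the compounds with values here, the only measured step, a 2.8-fold higher number from compound 2 to compound 3 (0.45 log units; beyond the scatter), concerns the oxolane on an aromatic nitrogen, a different part of the molecule, so it offers no direct guide to a change on the chain. Since the chain still ends in a nitrogen bearing two methyl groups, the number for compound 4 is expected to move little, if at all: a 1.2-fold higher number from compound 1 to compound 4 (0.08 log units; within the scatter). Compound 4 is estimated at 1500 nM, with a range from 600 nM to 3500 nM.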

Compound 4, half-maximal inhibitory concentration: 220 nM
Compound 4: middle estimate off by 6.8-fold (0.83 log units), on the high side, and the stated range ends above it.
By their numbers in this assay, from the lowest: compound 4; then compound 2; then compounds 1 and 3 (each within the scatter of the next).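

In this assay, swapping the end of the chain gives a 5.7-fold lower number from compound 1 to compound 4 (0.76 log units; beyond the scatter), so this position responds to what the chain carries, even when an amine stays on it. The group that enters has no ring and fewer heavy atoms than the one that leaves, and this one pair cannot show which of those differences counts. Nothing available explains the change.

Still open, going by these compounds, is whether a smaller ring at this spot, such as pyrrolidine, would behave like dimethylamino. A morpholine ring or a diethylamino group could also test this.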